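Shortening the Ester Chain from Compound 1 to Compound 3

This account rests on a few compounds, and the source may have more. Where it says the series, first, only, none or still open, it means among the compounds named here.

Compound 1 `C/C=C1/[C@H](O[C@@H]2O[C@H](CO)[C@@H](O)[C@H](O)[C@H]2O)OC=C(C(=O)OC)[C@H]1CC(=O)OCCCCCCCCCCCCCCC` holds the only number shown in a functional assay on SK-BR-3 cells (Homo sapiens) for antiproliferative activity, read by MTT assay, with a stated time of 72 h; a lower number here means a stronger inhibitor, a higher number a weaker inhibitor; in this assay compound 1 gives 1600 nM. Compound 2 `C/C=C1/[C@H](O[C@@H]2O[C@H](COC(C)=O)[C@@H](OC(C)=O)[C@H](OC(C)=O)[C@H]2OC(C)=O)OC=C(C(=O)OC)[C@H]1CC(=O)OC` stands at the limit of > 15000 nM in this assay, at which 1 of the 2 values shown sits, and its value of > 15000 nM is a limit of the assay, not a number. Compound 3 `C/C=C1/[C@H](O[C@@H]2O[C@H](CO)[C@@H](O)[C@H](O)[C@H]2O)OC=C(C(=O)OC)[C@H]1CC(=O)OCCCC` differs from compound 1 by hydrogen in place of undecyl on a saturated chain carbon, four bonds along the chain from an oxygen next to a carbonyl group. No measured pair differs in one place, so the size of such a step is not shown. A weakening beyond the usual scatter is expected for compound 3, a 3.8-fold higher number from compound 1 to compound 3 (0.57 log units; beyond the scatter). Compound 3 is estimated at 6000 nM, between 2500 nM and 15000 nM.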

Compound 3, half-maximal inhibitory concentration: > 15000 nM
Compound 3 ended at the assay's limit; the forecaster's own chance of this, stated with the estimate: 30%; middle value at least 2.5-fold (0.39 log units) from the limit.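

Hydrogen in place of undecyl at this position gives the first readable step of the series: in this assay the change reads an at least 9.3-fold higher number from compound 1 to compound 3 (0.97 log units; beyond the scatter). On these data alone, the activity of compound 1 in this assay is thus lost once the chain is cut back, and the full size of the step stays unknown. The value of compound 3 is a limit of the assay, not a number: the limit of > 15000 nM in this assay, at which 2 of the 3 values shown sit.

As far as these compounds go, how an octyl chain, or a longer chain than that of compound 1, would read in this assay stays open. So does the effect of an amine or a carboxylic acid at the end of the chain.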